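The source may hold more compounds than are shown below. What is called first, only, known or untested is meant among the compounds shown, and "the series" means these compounds.

Within the data shown here, in a functional assay on FM3A cells (Mus musculus) for cytotoxicity (on this read-out higher numbers stand for an effect only at larger amounts of compound and lower numbers for an effect already at smaller amounts), compound 1 (`COOC1(OOC)CCCCCCCCCCC1`) gives 1500 nM, the lowest of the three numbers so far. Compound 2 (`CCCCOOC1(OOCCCC)CCCCCCCCCCC1`) gives 8500 nM and compound 3 (`C=CCOOC1(OOCC=C)CCCCCCCCCCC1`) gives 14000 nM, and both gaps to compound 1 lie beyond the scatter. Compound 4 (`CCOC(C)OOC1(OOC)CCCCCCCCCCC1`) puts 1-ethoxyethyl in place of methyl on an oxygen whose other neighbours are oxygen, keeping the second methyl: 1-ethoxyethyl in place of methyl on an oxygen. Among the measured compounds shown here, no measured pair isolates this change. Compound 2 and compound 3 differ from compound 1 at both such oxygens, whereas compound 4 differs at only one, so a moderate rise in this assay is expected, probably beyond the scatter. The expected step is a 2.7-fold higher number from compound 1 to compound 4 (0.43 log units; beyond the scatter). For compound 4, the estimated value is 4000 nM, with an expected range of 1300 nM to 13000 nM.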

Compound 4, half-maximal effective concentration: 12000 nM
Estimate against measurement, compound 4: 3.0-fold (0.48 log units) below; the range from low to high includes it.
By their numbers in this assay, from the lowest: compound 1; then compounds 2, 4 and 3 (each within the scatter of the next).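

In this assay, replacing one methyl with 1-ethoxyethyl on an oxygen whose other neighbours are oxygen, with the second methyl kept, gives an 8.0-fold higher number from compound 1 to compound 4 (0.90 log units; beyond the scatter) as the first step read at this position. It shows that changing one such oxygen alone moves the number beyond the scatter. No evidence at hand explains this step.

From the compounds shown here alone, it remains open whether a plain ethyl on that oxygen would move the number as far. The same applies to a chain ending in an amine.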